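A few compounds are considered here, and "the series" means these few. Any claim that something is new, unique, unknown or untested is made for them only; others in the source may bear on it.

Three compounds share one core, an amide carried on a ring that holds an amine nitrogen, with a varying group on a saturated chain carbon bound to that nitrogen, and all were tested in an assay on isolated protein for binding affinity to melanin-concentrating hormone receptor 1 (Homo sapiens); on this read-out lower numbers stand for stronger inhibition and higher numbers for weaker inhibition. Compound 1 `COc1cc(OC)cc(C(=O)NC2CCN(Cc3ccc4ccccc4c3)CC2)c1` gives 27 nM. Compound 2 `COc1cc(OC)cc(C(=O)NC2CCN(Cc3cc4ccccc4n3C)CC2)c1` gives 142 nM, and compound 3 `COc1cc(OC)cc(C(=O)NC2CCN(CC3CCc4ccccc4C3)CC2)c1` gives 136 nM. Compound 3 therefore sits alongside compound 2, the two being within the scatter of each other, and well away from compound 1. Compound 4 `COc1cc(OC)cc(C(=O)NC2CCN(CCCc3ccccc3)CC2)c1` has not yet been measured; the change from compound 3 is phenethyl in place of 1,2,3,4-tetrahydronaphthalen-2-yl on a saturated chain carbon bound to an amine nitrogen in a ring. The steps of a 5.3-fold higher number from compound 1 to compound 2 (0.72 log units; beyond the scatter) and a 5.0-fold higher number from compound 1 to compound 3 (0.70 log units; beyond the scatter) both show a modest loss when the naphthalen-2-yl group is replaced, while a 1.0-fold lower number from compound 2 to compound 3 (0.02 log units; within the scatter) shows no real difference between the two replacements. The present change goes further, trimming the group to a phenethyl, and a further modest weakening is expected rather than none. For compound 4 the expected step is a 2.2-fold higher number from compound 3 to compound 4 (0.34 log units; beyond the scatter). Compound 4 is estimated at 300 nM, with a range from 100 nM to 1000 nM.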

Compound 4, inhibition constant: > 100000 nM
Compound 4: only a limit was reported (the forecaster's own chance of this, stated with the estimate: 5%); at least 330-fold (2.52 log units) between middle value and limit.
By their numbers in this assay, from the lowest: compound 1; then compounds 3 and 2 (each within the scatter of the next). At a limit, above all of these: compound 4.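

In this assay compound 4 gives no number, only a limit of the assay: the limit of > 100000 nM in this assay, at which 1 of the 4 values shown sits. Swapping among naphthalen-2-yl, 1-methyl-1H-indol-2-yl and 1,2,3,4-tetrahydronaphthalen-2-yl had moved the number modestly or not beyond the scatter, so this place on a saturated chain carbon bound to an amine nitrogen in a ring looked tolerant, but phenethyl gives far larger steps: an at least 730-fold higher number from compound 3 to compound 4 (2.86 log units; beyond the scatter), an at least 700-fold higher number from compound 2 to compound 4 (2.84 log units; beyond the scatter) and an at least 3700-fold higher number from compound 1 to compound 4 (3.56 log units; beyond the scatter). Phenethyl keeps the six-membered aromatic ring and loses the non-aromatic one, and neither group has hydrogen-bond donors, acceptors or net charge, so a small change in the group's structure can separate measurable binding from none detected here.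

These compounds cannot tell whether the loss comes from the missing non-aromatic ring or from the open chain itself. Nor do they show how a shorter benzyl group, a longer chain ending in phenyl, or an added amine on the phenyl ring would behave.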